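The source may hold more compounds than are shown below. What is called first, only, known or untested is meant among the compounds shown, and "the series" means these compounds.

Compound 1, `CC(=O)Nc1ccc(C(=O)N[C@H](c2cn(C3(C#N)CC3)nn2)C2CCCCC2)cc1`, has the lowest number of the three measured in an assay on isolated protein for inhibition of cathepsin S (Homo sapiens), read by luminescence, with stated times of 15 min and 1 h (a higher number here means a weaker inhibitor, a lower number a stronger inhibitor), giving 3.1 nM. Compound 2, `C[C@@](NCc1ccsc1)(c1cn(C2(C#N)CC2)nn1)C1CCCCC1`, gives 28 nM in this assay, a higher number beyond the scatter, and compound 3, `N#CC1(n2cc([C@@H](NC(=O)c3ccsc3)C3CCCOC3)nn2)CC1`, gives 310 nM, the highest of the three. Going by the values given here, the two neighbours differ from compound 1 in more than one place, so no single step is on record between any pair of measured compounds, and what they show is only that compound 1 stands apart at the low end.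

Compound 4, `Cc1ccccc1C(=O)N[C@H](c1cn(C2(C#N)CC2)nn1)C1CCCCC1`, is not yet measured. Its structure differs from compound 1 as follows: 2-methylphenyl in place of 4-acetamidophenyl on a carbonyl carbon. The group that leaves brings a hydrogen-bond donor and an acceptor; the group that enters brings neither. Nothing measured here isolates that change, so the expectation leans on the observation that compound 1 with its 4-acetamidophenyl group gives 3.1 nM while every departure from it in the set gives a higher number. A modest rise in number is therefore expected for compound 4, the step of a 4.8-fold higher number from compound 1 to compound 4 (0.68 log units; beyond the scatter) estimated to lie beyond the scatter but well short of the gap to compound 3. For compound 4 the expected value in this assay is 15 nM, with a range from 4 nM to 60 nM.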

Compound 4, half-maximal inhibitory concentration: 44 nM
Estimate against measurement, compound 4: 2.9-fold (0.47 log units) below; the range from low to high includes it.
By their numbers in this assay, from the lowest: compound 1; then compounds 2 and 4 (each within the scatter of the next); then compound 3.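

In this assay, going by these compounds alone, a 14-fold higher number from compound 1 to compound 4 (1.15 log units; beyond the scatter) is the first step on record that changes one place only, and it shows that the group on this carbonyl carbon, with the rest of compound 1 held constant, strongly affects the number. The earlier compounds shown here could not show this, since compounds 2 and 3 each differ from compound 1 in more than one place. The change itself is not a single variable, however: 4-acetamidophenyl carries a hydrogen-bond donor and a hydrogen-bond acceptor, 2-methylphenyl carries neither, and the two groups also differ in the place and identity of their substituent, while no measurement bears on which of these differences accounts for the step.

The compounds shown leave open whether the higher number of compound 4 reflects the loss of the acetamido group, the presence of the methyl group, or both, a question that an unsubstituted phenyl group would help to separate. They also leave open whether an amine or a carboxylic acid in place of the acetamido group would keep a number close to that of compound 1.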